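The compounds below may be only part of what the source reports. "The series", "measured", "known", "first", "only" and "open" are said of these compounds alone.

Working notes on the series of compound 1 `OC[C@H]1O[C@@H](n2cnc3c(NCc4ccc(F)cc4)ncnc32)[C@H](O)[C@@H]1O`, in which the aromatic group on a saturated chain carbon bound to a nitrogen on an aromatic ring is varied. Going by the values given here, in a functional assay on HOS cells (Homo sapiens) for antiproliferative activity, with a stated time of 72 h (on this read-out higher numbers stand for weaker inhibition and lower numbers for stronger inhibition), compound 1 gives 13200 nM, the only number in the set. Compound 2 `OC[C@H]1O[C@@H](n2cnc3c(NCc4ccccc4Cl)ncnc32)[C@H](O)[C@@H]1O` reaches only a limit, > 166000 nM. Compound 3 `COc1cccc(CNc2ncnc3c2ncn3[C@@H]2O[C@H](CO)[C@@H](O)[C@H]2O)c1` likewise reaches only a limit, > 166000 nM. Two of the three values thus sit at the same point, (the limit of > 166000 nM in this assay, at which 2 of the 3 values shown sit), and between them a step that the two limits leave unreadable from compound 2 to compound 3. Compound 4 `COc1cccc(CNc2ncnc3c2ncn3[C@@H]2O[C@H](CO)[C@@H](O)[C@H]2O)c1OC` is not yet measured in this assay. Its change from compound 1: 2,3-dimethoxyphenyl in place of 4-fluorophenyl on a saturated chain carbon bound to a nitrogen on an aromatic ring. Bearing on this are an at least 12-fold higher number from compound 1 to compound 2 (1.09 log units; beyond the scatter) and an at least 12-fold higher number from compound 1 to compound 3 (1.09 log units; beyond the scatter), both large, both towards higher numbers; the 3-methoxyphenyl of compound 3 is contained in the entering group. A step of similar size and direction, beyond the scatter, is therefore expected, and the result may again be a limit. The estimate for compound 4 is 170000 nM, range 40000 nM to 500000 nM. The expected step is a 13-fold higher number from compound 1 to compound 4 (1.11 log units; beyond the scatter).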

Compound 4, half-maximal inhibitory concentration: > 166000 nM
Compound 4: no number, only a limit (the forecaster's own chance of this, stated with the estimate: 65%); the middle value lies beyond the limit too.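

In this assay, the 2,3-dimethoxyphenyl group gives an at least 12-fold higher number from compound 1 to compound 4 (1.09 log units; beyond the scatter), so the loss seen with the 2-chlorophenyl and 3-methoxyphenyl groups extends to a group carrying two methoxy substituents. Methoxy in place of hydrogen on an aromatic carbon, the change from compound 3 to compound 4, does not restore a number; that step and the one from compound 2 to compound 4 cannot be read, with limits at both ends. Going by these compounds alone, compound 1 remains the only compound with a number, and the other three coincide at a single point: the limit of > 166000 nM in this assay, at which 3 of the 4 values shown sit.

From the compounds shown here alone, how far compounds 2, 3 and 4 lie beyond that limit stays open. Also open, going by these compounds, is whether the fluorine of the 4-fluorophenyl is what sets compound 1 apart, and how an unsubstituted phenyl, a pyridyl or a longer chain would read in this place.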